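The compounds below may be only part of what the source reports. "The series", "measured", "known", "first", "only" and "open" are said of these compounds alone.

Compound 2 `CN(CCNCc1cn(Cc2nc3ccccc3[nH]2)nn1)CCNc1ccnc2cc(Cl)ccc12` stands at the higher end of the two numbers measured here. In a functional assay on HCC827 cells (Homo sapiens) for antiproliferative activity, read by sulforhodamine B assay, with a stated time of 72 h (on this read-out higher numbers stand for weaker inhibition and lower numbers for stronger inhibition), compound 2 gives 164000 nM, while compound 1 `CN(CCNCc1cn(-c2ccccc2)nn1)CCNc1ccnc2cc(Cl)ccc12` gives 26000 nM. Among the compounds with values here, the only measured step, a 6.3-fold higher number from compound 1 to compound 2 (0.80 log units; beyond the scatter), came from putting (1H-benzimidazol-2-yl)methyl in place of phenyl on an aromatic nitrogen. Compound 3 `CN(CCNCc1cn(CCC(=O)Nc2ccccn2)nn1)CCNc1ccnc2cc(Cl)ccc12` is not yet measured; it differs from compound 2 by ((pyridin-2-yl)carbamoyl)methyl in place of 1H-benzimidazol-2-yl on a saturated chain carbon bound to an aromatic nitrogen. That step only partly resembles the measured one, since the benzimidazole that was added in compound 2 is now itself replaced by a different group, so the measured step bears on it loosely. With compound 2 being the weaker of the two measured compounds, a modest move toward a lower number is expected for compound 3, though a change within the scatter would not surprise. The estimated step is a 2.1-fold lower number from compound 2 to compound 3 (0.31 log units; beyond the scatter). For compound 3 the expected value in this assay is 80000 nM, with a range from 25000 nM to 260000 nM.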

Compound 3, half-maximal inhibitory concentration: > 200000 nM
Compound 3: no number, only a limit (the forecaster's own chance of this, stated with the estimate: 30%); middle value at least 2.5-fold (0.39 log units) away from the limit.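

Compound 3 gives no number, only a limit: the limit of > 200000 nM in this assay, at which 1 of the 3 values shown sits. Swapping the benzimidazole for the pyridine amide gives an at least 1.2-fold higher number from compound 2 to compound 3 (0.08 log units; that floor lies within the scatter), so this floor alone does not separate compound 3 from compound 2. The comparison with phenyl is clearer, at an at least 7.6-fold higher number from compound 1 to compound 3 (0.88 log units; beyond the scatter), and it shows that a second, quite different group carried on a saturated chain also ends up with a higher number than compound 1, so among these three compounds the phenyl of compound 1 gives the lowest number.

From the compounds shown here alone, the true position of compound 3 relative to compound 2 remains unknown, as does whether the loss follows the saturated chain or the ring it carries. A benzyl group on the same aromatic nitrogen, or a short chain ending in an amine or a carboxylic acid, would help tell these apart.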